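The source may hold more compounds than are shown below. What is called first, only, known or untested is meant among the compounds shown, and "the series" means these compounds.

Measured compounds in hand:

- compound 1, `Cc1ccc(-n2cc(C(=O)Nc3cc(F)cc(F)c3)c(=O)c3ccc(N(C)C)nc32)cc1OCCCCCCC[n+]1ccccc1`: 22.2%
- compound 2, `CN(C)c1ccc2c(=O)c(C(=O)Nc3cc(F)cc(F)c3)cn(-c3ccc(Cl)c(OCCCCCCC[n+]4ccccc4)c3)c2n1`: 77.9%
- compound 3, `CC[N+]1(CCCCCCCOc2ccc(-n3cc(C(=O)Nc4cc(F)cc(F)c4)c(=O)c4ccc(N(C)C)nc43)c(C)c2)CCCCC1`: "not active" (no number reported)

All three were run in an assay on LX2 cells for inhibition of COL1A1 promoter (Homo sapiens), read by a luciferase reporter, with a stated time of 24 h, tested at 50 uM; on this read-out lower numbers stand for a weaker effect and higher numbers for a stronger effect at the one concentration tested. Compound 1 and compound 2 share one core and differ by a single change, (chloro in place of methyl on an aromatic carbon). That change gave a number 55.7 percentage points higher from compound 1 to compound 2 (beyond the scatter), a step well outside the usual scatter. Compound 3 carries a different core; how its core differs from that of compound 1 is not broken down here. In this assay compound 3 is reported as not active, with no number given.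

Compound 4, `CC[N+]1(CCCCCCCOc2ccc(-n3cc(C(=O)Nc4cc(F)cc(F)c4)c(=O)c4ccc(N(C)C)nc43)c(Cl)c2)CCCCC1`, is not yet measured. It stands to compound 3 as compound 2 stands to compound 1: the change is chloro in place of methyl on an aromatic carbon. The two changes are the same kind of change, not the same: in compound 1 the site is ortho to a large group and para to a large group, in compound 3 it is ortho to a large group and meta to a large group.

Among the measured compounds shown here, on the core of compound 1 the step from methyl to chloro was large, so a rise is expected for compound 4 as well, but the starting point of compound 3 is a "not active" report rather than a number, and only one pair shows the step. Compound 4 is therefore expected to land near 35% in this assay, with a broad range estimated from 0% to 75%.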

Compound 4, a percentage reported as inhibition, at one concentration (the size of the read-out at that concentration, not a potency): "not active" (no number reported)
For compound 4 the study gives words and no number; no gap can be computed for the estimate.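

Among the compounds shown here, compound 3 and compound 4 are both reported without a number in this assay, and no step from methyl to chloro can be read for this pair. The compounds shown leave open whether chloro in place of methyl has any effect on the core of compound 3 at all. No supporting evidence bears on this result.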